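This account rests on a few compounds, and the source may have more. Where it says the series, first, only, none or still open, it means among the compounds named here.

Compound 1 `Nc1nc(C(F)(F)F)cc2c1[nH]c(=O)n2Cc1ccc(NCc2ccccc2)nc1` is the reference point of this set. In an in vitro ADME assay on microsomes from liver (Rattus norvegicus) for pharmacokinetics (a lower number here means slower removal, a higher number faster removal of the compound), compound 1 gives 16 mL.min-1.g-1, the highest of the two numbers in hand, with compound 3 sitting within the scatter of it. Compound 2 `Nc1nc(C(F)(F)F)cc2c1[nH]c(=O)n2Cc1ccc(NCCN2CCCC2)nc1` returns only a limit in this assay, < 8.5 mL.min-1.g-1. That value is the limit of < 8.5 mL.min-1.g-1 in this assay, at which 1 of the 3 values shown sits. Compound 3 `CN1CCN(CCN(C)c2ccc(Cn3c(=O)[nH]c4c(N)nc(C(F)(F)F)cc43)cn2)CC1` gives 15 mL.min-1.g-1 in this assay. The measured steps are an at least 1.8-fold lower number from compound 1 to compound 2 (0.27 log units; that floor lies within the scatter), a 1.1-fold lower number from compound 1 to compound 3 (0.03 log units; within the scatter) and an at least 1.7-fold higher number from compound 2 to compound 3 (0.24 log units; that floor lies within the scatter); none of them is secure beyond the scatter.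

Compound 4 `CN(C)CCN1CCN(c2ccc(Cn3c(=O)[nH]c4c(N)nc(C(F)(F)F)cc43)cn2)CC1` is not yet measured. Relative to compound 1 it carries 4-(2-(dimethylamino)ethyl)piperazin-1-yl in place of benzylamino on an aromatic carbon. Two of the measured steps bear on this change. Replacing benzylamino with a chain carrying a saturated nitrogen ring gave a 1.1-fold lower number from compound 1 to compound 3 (0.03 log units; within the scatter), and replacing phenyl with a saturated nitrogen ring gave an at least 1.8-fold lower number from compound 1 to compound 2 (0.27 log units; that floor lies within the scatter). Compound 4 joins both features in one group, so a small lowering of the number at most, or no shift beyond the scatter, is expected in this assay. The estimated step is a 1.5-fold lower number from compound 1 to compound 4 (0.16 log units; within the scatter). The estimate for compound 4 in this assay is 11 mL.min-1.g-1, with a range from 6 mL.min-1.g-1 to 22 mL.min-1.g-1.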

Compound 4, intrinsic clearance in microsomes: < 8.5 mL.min-1.g-1
Compound 4: a limit, no number; the forecaster's own chance of this, stated with the estimate: 30%; at least 1.2-fold (0.11 log units) between middle value and limit.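

In this assay compound 4 returns a limit and no number, making it the second compound in the series to do so: the limit of < 8.5 mL.min-1.g-1 in this assay, at which 2 of the 4 values shown sit.

The limit now also appears with 4-(2-(dimethylamino)ethyl)piperazin-1-yl on the aromatic carbon, a group with 0 hydrogen-bond donors, and not only with the (2-(pyrrolidin-1-yl)ethyl)amino chain of compound 2. The change from benzylamino gives an at least 1.8-fold lower number from compound 1 to compound 4 (0.27 log units; that floor lies within the scatter), and the change from methyl(2-(4-methylpiperazin-1-yl)ethyl)amino gives an at least 1.7-fold lower number from compound 3 to compound 4 (0.24 log units; that floor lies within the scatter), so neither floor is secure, although a piperazine-bearing group no longer goes with a single reading in this series. The step between compound 2 and compound 4 cannot be read, since both values are limits.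

As far as these compounds go, how far the true values of compound 2 and compound 4 lie from the limit stays open, and with it the real size of both readable steps. Also open, from the compounds shown here alone, is whether a plain 4-methylpiperazin-1-yl or a morpholin-4-yl on the same aromatic carbon would reach the limit too, which would show whether the dimethylaminoethyl chain is needed for this reading.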